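The source may hold more compounds than are shown below. What is called first, only, known or untested is meant among the compounds shown, and "the series" means these compounds.

Measured compounds:
- compound 1 `CNC(=O)[C@@]12C[C@@H]1[C@@H](n1cnc3c(NC)nc(C#Cc4ccccc4F)nc31)[C@H](O)[C@@H]2O`: 20%
- compound 2 `CNC(=O)[C@@]12C[C@@H]1[C@@H](n1cnc3c(NC)nc(C#Cc4cc(C)c(C)o4)nc31)[C@H](O)[C@@H]2O`: 15%
- compound 3 `CCc1ccc(C#Cc2nc(NC)c3ncn([C@H]4[C@H](O)[C@H](O)[C@]5(C(=O)NC)C[C@H]45)c3n2)o1`: 18%

In an assay on CHO cells for displacement of a labelled ligand from adenosine receptor A1 (Homo sapiens), read by scintillation counting, with a stated time of 60 min, tested at 10 uM (on this read-out lower numbers stand for less inhibition and higher numbers for more inhibition at the one concentration tested (going by the name of the read-out)), compound 1 gives 20%, the highest of the three numbers, but neither of the other two is separated from it beyond the scatter: compound 3 stands nearest, a number 2 percentage points lower from compound 1 to compound 3 (within the scatter), and compound 2 furthest, a number 5 percentage points lower from compound 1 to compound 2 (within the scatter). All three replacements of the group on the triple-bonded carbon therefore read as one flat set in this assay.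

Compound 4 `CNC(=O)[C@@]12C[C@@H]1[C@@H](n1cnc3c(NC)nc(C#Cc4ccsc4)nc31)[C@H](O)[C@@H]2O` is the next member. Its change from compound 1: thiophen-3-yl in place of 2-fluorophenyl on a triple-bonded carbon

The two steps that bear on it are the earlier swaps of the 2-fluorophenyl at the same place, a number 5 percentage points lower from compound 1 to compound 2 (within the scatter) and a number 2 percentage points lower from compound 1 to compound 3 (within the scatter), both within the scatter. Nothing in the series suggests that a thiophen-3-yl would behave differently from the furanyl groups already tried, so no step beyond the scatter is expected for compound 4: a number 3 percentage points lower from compound 1 to compound 4 (within the scatter) is the estimated step. Compound 4 is expected to give about 17% in this assay, in the range 5% to 30%.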

Compound 4, a percentage reported as inhibition, at one concentration (the size of the read-out at that concentration, not a potency): 11%
Compound 4: the middle estimate sits 6 percentage points above what was measured; the range from low to high includes it.
By their numbers in this assay, from the lowest: compounds 4, 2, 3 and 1 (each within the scatter of the next).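

In this assay the change to thiophen-3-yl on this triple-bonded carbon gives a number 9 percentage points lower from compound 1 to compound 4 (within the scatter) and also a number 7 percentage points lower from compound 3 to compound 4 (within the scatter) and a number 4 percentage points lower from compound 2 to compound 4 (within the scatter) so thiophen-3-yl joins 2-fluorophenyl, 4,5-dimethylfuran-2-yl and 5-ethylfuran-2-yl in one flat set. The position has now carried a six-membered aromatic ring of carbon only and five-membered aromatic rings with oxygen or sulfur as the hetero atom, with no step beyond the scatter. No measurement at hand accounts for these numbers.

From the compounds shown here alone, whether an amine or a carboxylic acid on the ring, or a plain alkyl chain in place of the ring, would give a step beyond the scatter remains open. Also open, going by these compounds, is whether the same groups stay this close at other concentrations, since a single-concentration percentage is not a potency.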